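The compounds below may be only part of what the source reports. "The series", "measured", "known", "first", "only" and "open" are said of these compounds alone.

Working notes on the series, read in a functional assay on KYSE-410 cells (Homo sapiens) for antiproliferative activity, read by MTT assay, with a stated time of 72 h; a lower number here means a stronger inhibitor, a higher number a weaker inhibitor. Compound 1 (`O=C(Nc1cccc(F)c1)c1cc(=O)[nH]c2cc(F)ccc12`) carries fluoro on the shared core and gives > 20000 nM, which is a limit and not a number. Compound 3 (`O=C(Nc1cccc(F)c1)c1cc(=O)[nH]c2cc(C3CC3)ccc12`) carries cyclopropyl at that carbon and gives > 20000 nM, again a limit and not a number. Within the data shown here, compound 2 (`O=C(Nc1cccc(F)c1)c1cc(=O)[nH]c2cc(-c3ccc(F)cc3)ccc12`), with 4-fluorophenyl there, gives 10300 nM, the one true number so far. Compound 3 therefore stands at the limit of > 20000 nM in this assay, at which 2 of the 3 values shown sit.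

Compound 4 (`O=C(Nc1cccc(F)c1)c1cc(=O)[nH]c2cc(-c3ccncc3)ccc12`) has pyridin-4-yl in place of cyclopropyl on an aromatic carbon.

The closest measured change is 4-fluorophenyl to cyclopropyl, which gave an at least 1.9-fold higher number from compound 2 to compound 3 (0.28 log units; that floor lies within the scatter). Fluoro to 4-fluorophenyl gave an at least 1.9-fold lower number from compound 1 to compound 2 (0.28 log units; that floor lies within the scatter), and fluoro to cyclopropyl gave a step that the two limits leave unreadable from compound 1 to compound 3. These steps set floors only, so they support a modest expectation. Compound 4 shares with compound 2 an aromatic ring at this carbon, and the reading for compound 2 of 10300 nM is the basis for expecting compound 4 to read lower than compound 3. The expected change is an at least 1.6-fold lower number from compound 3 to compound 4 (0.22 log units; that floor lies within the scatter), and it may not clear the scatter. The estimate for compound 4 is 12000 nM, with an expected range of 5000 nM to 20000 nM.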

Compound 4, half-maximal inhibitory concentration: > 20000 nM
Compound 4 ended at the assay's limit; the forecaster's own chance of this, stated with the estimate: 35%; middle value at least 1.6-fold (0.22 log units) away from the limit.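

In this assay compound 4 gives > 20000 nM, which is a limit and not a number. An aromatic ring at this carbon therefore does not by itself bring a reading inside the measurable range, and the change from 4-fluorophenyl to pyridin-4-yl gives an at least 1.9-fold higher number from compound 2 to compound 4 (0.28 log units; that floor lies within the scatter), so a real gain for compound 2 over this pyridine analogue is not established. The steps to compound 4 from compound 1 and from compound 3 cannot be read, and compound 2 stays the only compound with a true number, while the others gather at one limit: the limit of > 20000 nM in this assay, at which 3 of the 4 values shown sit.

Among these compounds, how far compound 1, compound 3 and compound 4 lie beyond that limit stays open, so no order among them can be stated, and the single true number cannot show whether the aromatic ring, its fluoro or the absence of a ring nitrogen matters most. Plain phenyl at this carbon would separate the fluoro from the ring itself, and 4-aminophenyl or 4-carboxyphenyl would show whether other substituents on that ring move the reading at all.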